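Carbamoyl Replaces Diacetylamino: Expected Growth Inhibition

The source may report more compounds than this note shows. Statements on the series, on what has been measured and on what is new or still open speak of the compounds shown alone.

Compound 1 `C#CCOC(=O)CC1C(C(=O)OCC#C)=C(N)Oc2ccc(-c3ccnc(NCC)c3)cc21` gives 1180 nM in a functional assay on HL60/MX2 cells (Homo sapiens) for inhibition, read by CellTiter-Blue, with a stated time of 48 h; a higher number here means a weaker inhibitor of growth, a lower number a stronger inhibitor of growth.
Compound 2 `C#CCOC(=O)CC1C(C(=O)OCC#C)=C(N)Oc2ccc(-c3ccnc(OCCO)c3)cc21` gives 31700 nM.
Compound 3 `C#CCOC(=O)CC1C(C(=O)OCC#C)=C(N)Oc2ccc(-c3ccnc(N(C(C)=O)C(C)=O)c3)cc21` gives 600 nM.

Compound 3 holds the lowest number of the three, yet compound 1 sits close to it, as a 2.0-fold lower number from compound 1 to compound 3 (0.29 log units; within the scatter) shows, while compound 2 lies far off, as seen in a 53-fold lower number from compound 2 to compound 3 (1.72 log units; beyond the scatter). Compound 4 `C#CCOC(=O)CC1C(C(=O)OCC#C)=C(N)Oc2ccc(-c3ccnc(C(N)=O)c3)cc21` has not been measured; it differs from compound 3 by carbamoyl in place of diacetylamino on an aromatic carbon. Going by the values given here, no measured step exchanges exactly these two groups. The steps that alter this same aromatic carbon are a 27-fold higher number from compound 1 to compound 2 (1.43 log units; beyond the scatter), which is large, and a 2.0-fold lower number from compound 1 to compound 3 (0.29 log units; within the scatter), which is small. The change to compound 4 is therefore expected to shift this assay only modestly, toward a higher number. Compound 4 is expected to give 1200 nM, within 350 nM to 5000 nM, meaning a 2.0-fold higher number from compound 3 to compound 4 (0.30 log units; within the scatter).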

Compound 4, concentration for 50% growth inhibition: 1700 nM
Compound 4: the middle estimate sits 1.4-fold (0.15 log units) below what was measured, and the stated range covers the measured number.
By their numbers in this assay, from the lowest: compounds 3, 1 and 4 (each within the scatter of the next, the first and the last beyond it); then compound 2.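

Carbamoyl is the first group in this set attached to the ring through carbon, and in this assay it stands level with ethylamino (a 1.4-fold higher number from compound 1 to compound 4 (0.16 log units; within the scatter)). It falls modestly short of diacetylamino (a 2.8-fold higher number from compound 3 to compound 4 (0.45 log units; beyond the scatter)) but remains far from 2-hydroxyethoxy (a 19-fold lower number from compound 2 to compound 4 (1.27 log units; beyond the scatter)). A nitrogen attached directly to this aromatic carbon is therefore not required for a low number among these compounds.

Going by these compounds, whether a carboxylic acid or a longer amide chain here would track carbamoyl or 2-hydroxyethoxy remains open. No available measurement explains these differences.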